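Working notes: bromo in place of hydrogen toward compound 4

A few compounds are considered here, and "the series" means these few. Any claim that something is new, unique, unknown or untested is made for them only; others in the source may bear on it.

Measured so far in a functional assay on PC-3 cells (Homo sapiens) for cytotoxicity; a lower number here means a stronger inhibitor, a higher number a weaker inhibitor:
compound 1 `COc1ccc(Cn2cc(/C=N\NC(=O)c3c[nH]c4ccccc34)c3cc(OC)ccc32)cc1` gives 13600 nM
compound 2 `O=C(N/N=C\c1cn(Cc2ccc(Cl)cc2)c2cc(F)ccc12)c1c[nH]c2ccccc12` gives 19500 nM
compound 3 `O=C(N/N=C\c1cn(Cc2ccc(Cl)cc2)c2ccccc12)c1c[nH]c2ccccc12` gives 16200 nM

Compound 2 has the highest of the three numbers, but its nearest neighbour, compound 3, sits a 1.2-fold lower number from compound 2 to compound 3 (0.08 log units; within the scatter) away, and compound 1 is also within the scatter of compound 2. The three measured compounds therefore cannot be ranked against one another on these values.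

The next compound, compound 4 `O=C(N/N=C\c1cn(Cc2ccc(Cl)cc2)c2cc(F)ccc12)c1c[nH]c2ccc(Br)cc12`, arises from compound 2 by the change (bromo in place of hydrogen on an aromatic carbon). Cut one bond further out, the change reads 1H-indol-3-yl to 5-bromo-1H-indol-3-yl.

Among the compounds with values here, only one measured step exists, the one from compound 2 to compound 3, and it concerns a different place in the molecule: hydrogen in place of fluoro, with a size of a 1.2-fold lower number from compound 2 to compound 3 (0.08 log units; within the scatter). Within the data shown here, no measured step touches the ring that carries the new bromo, so the data offer no direct precedent for this change. Given that the one step on record stays within the scatter and that all three measured values cluster together, a step in this assay of no more than the scatter is expected here, in either direction.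

The expected value for compound 4 is 17000 nM, with a range from 8000 nM to 36000 nM. The corresponding expected step is a 1.1-fold lower number from compound 2 to compound 4 (0.06 log units; within the scatter).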

Compound 4, half-maximal inhibitory concentration: 12400 nM
Beside the measured number, compound 4's estimate is 1.4-fold (0.14 log units) above it; low and high end bracket the measured number.
By their numbers in this assay, from the lowest: compounds 4, 1, 3 and 2 (each within the scatter of the next).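

In this assay, within the data shown here, bromo in place of hydrogen on the aromatic carbon of the six-membered ring, turning 1H-indol-3-yl into 5-bromo-1H-indol-3-yl, gives a 1.6-fold lower number from compound 2 to compound 4 (0.20 log units; within the scatter) and supplies the first measured step at this place. Compounds 1, 2 and 3 all carry hydrogen here, so they could say nothing about substitution on this ring; compound 4 shows that a single bromine atom can be placed here while the read-out stays within the scatter of compound 2, and this one pair gives no sign that the position responds to the change. Nothing available bears on why the step is this size.

On these data alone, whether other groups at this place, such as an amine, a carboxylic acid or a nitrile, would give a step beyond the scatter remains open, as one substituent does not describe the tolerance of the position. Also open, as far as these compounds go, is whether bromo in place of hydrogen gives a similar step from compound 3, which has hydrogen in place of the fluoro of compound 2.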